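Trimming the alkyl branch on a cysteinyl leukotriene antagonist

The source may report more compounds than this note shows. Statements on the series, on what has been measured and on what is new or still open speak of the compounds shown alone.

Compound 1 `CCCC(CCc1nnn[nH]1)Cc1cccc(OCc2ccc3ccccc3n2)c1` holds the lower of the two numbers recorded in an assay on membranes from lung (Cavia porcellus) for binding affinity to cysteinyl leukotriene receptor (Homo sapiens); a higher number here means a weaker inhibitor, a lower number a stronger inhibitor: compound 1 gives 11 nM, while compound 2 `c1ccc2nc(COc3ccc(OCCCc4nnn[nH]4)cc3)ccc2c1` gives 69 nM in this assay, the two differing in more than one place, so their gap is noted only as it stands. Compound 3 `CC(CCc1nnn[nH]1)Cc1cccc(OCc2ccc3ccccc3n2)c1` has not yet been measured. It differs from compound 1 by hydrogen in place of ethyl on a saturated chain carbon, three bonds along the chain from an aromatic carbon. Among the compounds with values here, with no single-change step recorded, the author expects a modest loss in this assay, the step from compound 1 to compound 3 being estimated at a 2.7-fold higher number from compound 1 to compound 3 (0.44 log units; beyond the scatter). Compound 3 is therefore expected to give 30 nM, in the range 10 nM to 90 nM.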

Compound 3, inhibition constant: 34 nM
Compound 3: the middle estimate sits 1.1-fold (0.05 log units) below what was measured; the range from low to high includes it.
By their numbers in this assay, from the lowest: compound 1; then compound 3; then compound 2.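

In this assay, within the data shown here, the change from ethyl to hydrogen on a saturated chain carbon, three bonds along the chain from an aromatic carbon, gives a 3.1-fold higher number from compound 1 to compound 3 (0.49 log units; beyond the scatter) and is the first single-change reading at this position. The branch can thus be cut from propyl to methyl at a modest cost, with compound 1 keeping the lower number of the pair. Nothing available bears on the reason for this step. The compounds shown leave open how a butyl chain, a phenyl ring or a hydroxyl group would read on this carbon. They also leave open whether removing the remaining methyl of compound 3 would cost more.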